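Swapping furan for thiophene on a dihydropyrimidinone

The source may hold more compounds than are shown below. What is called first, only, known or untested is meant among the compounds shown, and "the series" means these compounds.

Measured compounds:
compound 1 `CC(=O)C1=C(C)NC(=O)NC1c1ccsc1`: 9%
compound 2 `CC1=C(C(N)=O)C(c2ccoc2)NC(=O)N1`: 1%

In an assay on membranes from CHO cells for displacement of a labelled ligand from adenosine receptor A1 (Homo sapiens), read by scintillation counting, with a stated time of 60 min, tested at 1 uM (a higher number here means more inhibition at the concentration tested (going by the name of the read-out), a lower number less inhibition), compound 2 gives 1%, the lowest of the two numbers, while compound 1 gives 9%, a reading within the scatter of compound 2. Compound 3 `CC1=C(C(N)=O)C(c2ccsc2)NC(=O)N1` has not been measured. It differs from compound 2 by thiophen-3-yl in place of furan-3-yl on a saturated ring carbon. Since compound 1 also carries the thiophen-3-yl group and shows only a small read-out, the step in this assay from compound 2 to compound 3 is expected to be a number 4 percentage points higher from compound 2 to compound 3 (within the scatter), no larger than the scatter. Compound 3 is therefore estimated at 5%, with a likely range from -6% to 16%.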

Compound 3, a percentage reported as inhibition, at one concentration (the size of the read-out at that concentration, not a potency): 2%
The estimate for compound 3 lay 3 percentage points above the measured number, and the stated range covers the measured number.
By their numbers in this assay, from the lowest: compounds 2, 3 and 1 (each within the scatter of the next).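

In this assay thiophen-3-yl in place of furan-3-yl on the saturated ring carbon gives a number 1 percentage points higher from compound 2 to compound 3 (within the scatter) and so does not separate the two groups at this position. With thiophen-3-yl kept in place, amino in place of methyl on the carbonyl carbon gives a number 7 percentage points lower from compound 1 to compound 3 (within the scatter) and this second change does not separate the two compounds either. Nothing measured here explains these readings.
From the compounds shown here alone, whether a phenyl group on that saturated ring carbon, or a carboxylic acid in place of the carbamoyl group, would give a reading beyond the scatter remains open.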